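Methoxy to Chloro on the Acetylated Amine

The compounds below may be only part of what the source reports. "The series", "measured", "known", "first", "only" and "open" are said of these compounds alone.

In a functional assay on K562 cells (Homo sapiens) for cytotoxicity, read by MTT assay, with a stated time of 48 h (a higher number here means a weaker inhibitor, a lower number a stronger inhibitor), compound 1 (`COc1ccc(-c2c(-c3cc(OC)c(OC)c(OC)c3)noc2N)cc1`) gives the lowest number (40 nM) and compound 2 (`COc1ccc(-c2c(-c3cc(OC)c(OC)c(OC)c3)noc2N)cc1OC`) the highest (1270 nM). Compound 3 (`COc1ccc(-c2c(-c3cc(OC)c(OC)c(OC)c3)noc2NC(C)=O)cc1`) stands second highest of the three (380 nM), making it a weaker inhibitor than compound 1 and a stronger one than compound 2.

Compound 4 (`COc1cc(-c2noc(NC(C)=O)c2-c2ccc(Cl)cc2)cc(OC)c1OC`) differs from compound 3 by chloro in place of methoxy on an aromatic carbon, turning 4-methoxyphenyl into 4-chlorophenyl. Among the compounds with values here, no measured step makes this exchange, so the evidence is indirect. The closest is another change on an aromatic carbon, methoxy in place of hydrogen, a large step (a 32-fold higher number from compound 1 to compound 2 (1.50 log units; beyond the scatter)). The acetyl group that compound 4 keeps accounts for a modest step (a 9.5-fold higher number from compound 1 to compound 3 (0.98 log units; beyond the scatter)). These steps show that single changes can move the number beyond the scatter, but neither gives a direction for this exchange. A small step is therefore expected (a 1.4-fold higher number from compound 3 to compound 4 (0.16 log units; within the scatter)), and its direction remains uncertain. Compound 4 is estimated at 550 nM (range 130 nM to 2300 nM).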

Compound 4, half-maximal inhibitory concentration: 3620 nM
The estimate for compound 4 lay 6.6-fold (0.82 log units) below the measured number; measured number above the stated range.
By their numbers in this assay, from the lowest: compound 1; then compound 3; then compound 2; then compound 4.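

In this assay, the position held by methoxy on compound 3 proves sensitive to exchange: chloro in place of methoxy, on an aromatic carbon para to a large group, gives a 9.5-fold higher number from compound 3 to compound 4 (0.98 log units; beyond the scatter). Within the data shown here, this is the first direct reading of the exchange, and it gives the direction the earlier steps could not: within this acetylated pair, methoxy gives the lower number and chloro the higher. No measurement here accounts for the shift.

Among these compounds, whether the same exchange would move the number as far on the free amine of compound 1 remains open, as the change is seen only with the acetyl group in place. From the compounds shown here alone, how a hydroxyl, a methyl, a fluoro or a dimethylamino group would compare with methoxy and chloro at this position is also open.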